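A few compounds are considered here, and "the series" means these few. Any claim that something is new, unique, unknown or untested is made for them only; others in the source may bear on it.

Measured compounds:
compound 1, `COc1cc(C(=O)c2cn(-c3cccc(C)c3)cc2-c2ccc([N+](=O)[O-])cc2)cc(OC)c1OC`, 780 nM in a functional assay on MCF7 cells (Homo sapiens) for cytotoxicity, read by MTT assay, with a stated time of 96 h; a higher number here means a weaker inhibitor, a lower number a stronger inhibitor
compound 2, `COc1cc(C(=O)c2cn(-c3cccc(C)c3)cc2-c2cccc(N)c2)cc(OC)c1OC`, 130 nM in this assay
compound 3, `COc1cc(C(=O)c2cn(-c3ccc(N)cc3)cc2-c2ccc([N+](=O)[O-])cc2)cc(OC)c1OC`, 260 nM in this assay

Compound 4, `COc1cc(C(=O)c2cn(-c3ccc(N)cc3)cc2-c2cccc(N)c2)cc(OC)c1OC`, has not yet been measured in this assay.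

The change from compound 1 to compound 2 is 3-aminophenyl in place of 4-nitrophenyl on an aromatic carbon. It gave a 6.0-fold lower number from compound 1 to compound 2 (0.78 log units; beyond the scatter). The same kind of change is made from compound 3 to compound 4, (3-aminophenyl in place of 4-nitrophenyl on an aromatic carbon). The two places are not identical word for word: in compound 1 the carbon lies two ring bonds from the ring atom that bears a 3-methylphenyl group, in compound 3 two ring bonds from the ring atom that bears a 4-aminophenyl group. That is how the two cores differ, (4-aminophenyl in place of 3-methylphenyl on an aromatic nitrogen), a change which gave a 3.0-fold lower number from compound 1 to compound 3 (0.48 log units; beyond the scatter). Compound 2 and compound 3 lie within the scatter of each other, so no order is claimed between them.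

For the measured compounds named here, for compound 4 the step of a 5.2-fold lower number from compound 3 to compound 4 (0.72 log units; beyond the scatter) is expected because a 6.0-fold lower number from compound 1 to compound 2 (0.78 log units; beyond the scatter) shows the same kind of change, and only one example of it is known, so the expected range is kept wide. Compound 4 is estimated at 50 nM, with a range from 15 nM to 160 nM.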

Compound 4, half-maximal inhibitory concentration: 78 nM
For compound 4 the middle estimate is 1.6-fold (0.19 log units) below the measured one; low and high end bracket the measured number.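

In this assay, 3-aminophenyl in place of 4-nitrophenyl on an aromatic carbon also lowers the number on the core bearing 4-aminophenyl (a 3.3-fold lower number from compound 3 to compound 4 (0.52 log units; beyond the scatter)), and the two examples of this change agree: the same change on two cores in this assay, a 6.0-fold lower number (0.78 log units; beyond the scatter) from compound 1 to compound 2 and a 3.3-fold lower number (0.52 log units; beyond the scatter) from compound 3 to compound 4, 1.8-fold (0.26 log units) apart, within the scatter of two such steps.
4-aminophenyl in place of 3-methylphenyl on an aromatic nitrogen gives a step that stays within the scatter on the core bearing 3-aminophenyl (a 1.7-fold lower number from compound 2 to compound 4 (0.22 log units; within the scatter)), yet it does not differ measurably from the earlier example of that change: the same change on two cores in this assay, a 3.0-fold lower number (0.48 log units; beyond the scatter) from compound 1 to compound 3 and a 1.7-fold lower number (0.22 log units; within the scatter) from compound 2 to compound 4, 1.8-fold (0.26 log units) apart, within the scatter of two such steps.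
These four compounds support transfer between these two cores only, with two examples of each change, and they do not show that either change would carry to any other core.

The carbon swap alters both the group and its place on the phenyl ring, so 3-nitrophenyl and 4-aminophenyl at that carbon would be needed to separate the two. Going by these compounds, how a hydroxyl or an amide would compare with the amine on either aryl group remains open.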